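A few compounds are considered here, and "the series" means these few. Any claim that something is new, unique, unknown or untested is made for them only; others in the source may bear on it.

Measured so far in a functional assay on SK-N-MC cells (Homo sapiens) for cytotoxicity, read by MTT assay; on this read-out lower numbers stand for stronger inhibition and higher numbers for weaker inhibition:

- compound 1, `O=C1/C(=C/c2ccc([N+](=O)[O-])cc2)CCC/C1=C\c1cccc([N+](=O)[O-])c1`: 17.9 ug/mL
- compound 2, `COc1cc(/C=C2\CCC/C(=C\c3ccc([N+](=O)[O-])cc3)C2=O)ccc1O`: 48 ug/mL

For the measured compounds named here, compound 2 stands at the highest of the two numbers; its only neighbour is compound 1, and the move between them is a 2.7-fold higher number from compound 1 to compound 2 (0.43 log units; beyond the scatter). The next member, compound 3 `O=C1/C(=C/c2ccc(Cl)cc2)CCC/C1=C\c1ccc([N+](=O)[O-])cc1`, is still to be measured. Its change from compound 2 is 4-chlorophenyl in place of 4-hydroxy-3-methoxyphenyl on a double-bonded chain carbon bound to a double-bonded ring carbon. Going by the values given here, one measured step bears on this: when 4-hydroxy-3-methoxyphenyl entered in place of 3-nitrophenyl, the number rose as a 2.7-fold higher number from compound 1 to compound 2 (0.43 log units; beyond the scatter). Among the compounds with values here, compound 3 removes that same group again, and no measured pair shows 4-chlorophenyl against any other group, so the direction rests on that single step alone. The expectation is that compound 3 moves back toward the region of compound 1, a step of a 2.4-fold lower number from compound 2 to compound 3 (0.38 log units; beyond the scatter). The estimate for compound 3 in this assay is 20 ug/mL, with a range from 9 ug/mL to 45 ug/mL.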

Compound 3, half-maximal inhibitory concentration: 14.1 ug/mL
For compound 3 the middle estimate is 1.4-fold (0.15 log units) above the measured one; measured number inside the range.
By their numbers in this assay, from the lowest: compounds 3 and 1 (each within the scatter of the next); then compound 2.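

In this assay, 4-chlorophenyl in place of 4-hydroxy-3-methoxyphenyl on a double-bonded chain carbon bound to a double-bonded ring carbon gives a 3.4-fold lower number from compound 2 to compound 3 (0.53 log units; beyond the scatter) and so shows that the earlier rise with 4-hydroxy-3-methoxyphenyl is not specific to a comparison with 3-nitrophenyl. The change from 3-nitrophenyl to 4-chlorophenyl gives a 1.3-fold lower number from compound 1 to compound 3 (0.10 log units; within the scatter) and leaves these two groups indistinguishable here, although they share no substituent, while 4-hydroxy-3-methoxyphenyl stands apart from both. Nothing at hand explains this separation.

The compounds shown do not separate the hydroxyl from the methoxy group within 4-hydroxy-3-methoxyphenyl, as neither appears alone on the phenyl ring. From the compounds shown here alone, how an amine or a carboxylic acid on that ring would read at this position remains open.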